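Amino-Linked Ring on the Carbonyl Carbon: Expecting Compound 3

The source may hold more compounds than are shown below. What is called first, only, known or untested is meant among the compounds shown, and "the series" means these compounds.

Measured so far:
compound 1, `COc1cc(Cl)cc(-c2nn(-c3cccc(NC(=O)c4ccc(Cl)c(Cl)c4)c3)cc2-c2ccncc2)c1`: 43.6%
compound 2, `COc1cc(Cl)cc(-c2nn(-c3cccc(NC(=O)Nc4ccc(Cl)c(C(F)(F)F)c4)c3)cc2-c2ccncc2)c1`: -27.5%

Both compounds were tested in a functional assay on SR cells (Homo sapiens) for inhibition, read by sulforhodamine B assay, with a stated time of 48 h, tested at 10 uM; a lower number here means a stronger effect, a higher number a weaker effect of the compound at the concentration tested. Going by the values given here, on the two numbers at hand compound 1 stands highest, that is, it shows the weaker effect of the pair; its only neighbour lies a number 71.1 percentage points lower from compound 1 to compound 2 (beyond the scatter), a large fall well beyond the scatter. That step put an amino-linked ring on the carbonyl carbon in place of a ring bound directly to it.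

Compound 3, `COc1cc(Cl)cc(-c2nn(-c3cccc(NC(=O)Nc4cccc(C(F)(F)F)c4)c3)cc2-c2ccncc2)c1`, is not yet measured. It differs from compound 1 in one place: (3-(trifluoromethyl)phenyl)amino in place of 3,4-dichlorophenyl on a carbonyl carbon. Among the compounds with values here, this is the same kind of change as the one seen in compound 2, except that the entering ring carries the trifluoromethyl but no chlorine, so the match is not exact. A step in the same downward direction is nonetheless expected for compound 3 because a number 71.1 percentage points lower from compound 1 to compound 2 (beyond the scatter) was large. The expected step is a number 53.6 percentage points lower from compound 1 to compound 3 (beyond the scatter). Compound 3 is accordingly estimated at -10%, with a likely range from -45% to 30%.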

Compound 3, a percentage reported as activity, at one concentration (the size of the read-out at that concentration, not a potency): -13.5%
The estimate for compound 3 lay 3.5 percentage points above the measured number; low and high end bracket the measured number.
By their numbers in this assay, from the lowest: compound 2; then compound 3; then compound 1.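

In this assay, the amino-linked ring still brings a large change when its ring carries no chlorine, with a number 57.1 percentage points lower from compound 1 to compound 3 (beyond the scatter); the large fall at this carbonyl carbon therefore does not require the chloro group that compound 2 carries. Going by these compounds alone, the chlorine still counts, though on a smaller scale: the single change of hydrogen in place of chloro on an aromatic carbon gives a number 14 percentage points higher from compound 2 to compound 3 (beyond the scatter), so the stronger effect goes with the chlorinated ring in this one pair. The data at hand offer no measurement that would explain either step.

The compounds shown leave open how much of the fall belongs to the amino link itself: both amino-linked compounds carry a trifluoromethyl, whereas compound 1 has two chlorines and no amino link, and a (3,4-dichlorophenyl)amino group on the same carbonyl carbon would separate these two parts of the change. Going by these compounds, it also remains open whether the trifluoromethyl can give way to another group, such as a nitrile or a methoxy, with the effect in this assay kept.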